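Swapping the Acetyl Cap on the Core Amine

A few compounds are considered here, and "the series" means these few. Any claim that something is new, unique, unknown or untested is made for them only; others in the source may bear on it.

Compound 1 `COc1ncc(-c2ccc3nc(NC(C)=O)nn3c2)cc1NS(=O)(=O)c1ccc(F)cc1` is one of three closely related compounds tested in a functional assay on U-87MG ATCC cells (Homo sapiens) for antiproliferative activity, read by MTT assay, with a stated time of 48 h; a higher number here means a weaker inhibitor, a lower number a stronger inhibitor. In this assay compound 1 gives 1820 nM, the lowest number of the three. Compound 2 `COc1ncc(-c2ccc3nc(NC(C)=O)nn3c2)cc1NS(=O)(=O)c1ccc(Cl)cc1` gives 2090 nM and compound 3 `COc1ncc(-c2ccc3nc(NC(C)=O)nn3c2)cc1NS(=O)(=O)c1ccc(C2CC2)cc1` gives 3730 nM. The step of a 1.1-fold higher number from compound 1 to compound 2 (0.06 log units; within the scatter) lies within the scatter, the step of a 2.0-fold higher number from compound 1 to compound 3 (0.31 log units; beyond the scatter) is a modest loss, and the step of a 1.8-fold higher number from compound 2 to compound 3 (0.25 log units; within the scatter) again falls within the scatter. All three of these steps concern the group on the aromatic ring of the sulfonamide; none touches the amine on the shared core.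

Compound 4 `CCOCCNc1nc2ccc(-c3cnc(OC)c(NS(=O)(=O)c4ccc(F)cc4)c3)cn2n1` differs from compound 1 elsewhere: 2-ethoxyethyl in place of acetyl on a nitrogen on an aromatic ring. For the measured compounds named here, no measured step bears on this change, so its direction cannot be read from the three compounds in hand. A small step is therefore expected, a 1.4-fold higher number from compound 1 to compound 4 (0.14 log units; within the scatter), with a wide allowance either way. The estimated value for compound 4 is 2500 nM, within a range from 600 nM to 10000 nM.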

Compound 4, half-maximal inhibitory concentration: 8150 nM
The estimate for compound 4 lay 3.3-fold (0.51 log units) below the measured number; measured number inside the range.
By their numbers in this assay, from the lowest: compounds 1, 2 and 3 (each within the scatter of the next, the first and the last beyond it); then compound 4.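

In this assay, for the compounds shown here, putting 2-ethoxyethyl in place of acetyl on a nitrogen on an aromatic ring gives a 4.5-fold higher number from compound 1 to compound 4 (0.65 log units; beyond the scatter), so this position, which the earlier steps on the aromatic ring of the sulfonamide left untouched, does respond to a change of group. The entering group has 5 heavy atoms against 3 for acetyl and lacks its double bond, while the counts of hydrogen-bond donors and acceptors stay the same, and this single pair cannot separate these differences. Nothing available explains the higher number.

As far as these compounds go, it remains open whether the loss follows from removing the acetyl or from adding the 2-ethoxyethyl chain; a free amine, a simple ethyl group or a longer acyl group such as propanoyl on this nitrogen would help to separate the two. Also open is whether the step would be similar with chloro or cyclopropyl on the sulfonamide's aromatic ring, as the change is shown here only with fluoro.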